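The source may report more compounds than this note shows. Statements on the series, on what has been measured and on what is new or still open speak of the compounds shown alone.

Working notes on the oxazole-carboxamide piperazine series.

In a functional assay on HL-60 cells (Homo sapiens) for inhibition, read by MTT assay, with a stated time of 72 h (on this read-out lower numbers stand for stronger inhibition and higher numbers for weaker inhibition), compound 2 `Cc1nc(-c2ccccc2)c(C(=O)N2CCN(c3cccc(Cl)c3Cl)CC2)o1` gives 133 nM. For the measured compounds named here, this is the only number so far: compound 1 `COc1ccc(-c2nc(C)oc2C(=O)N2CCN(c3cccc(Cl)c3)CC2)cc1` is reported in this assay as "not active" (no number reported), and compound 3 `COc1cccc(N2CCN(C(=O)c3oc(C)nc3-c3cccc(F)c3)CC2)c1` is reported in this assay as "not active" (no number reported), neither with a number, so no step between measured compounds can be put down and compound 2 stands alone as the single quantified point.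

The next entry, compound 4 `Cc1nc(-c2ccccc2)c(C(=O)N2CCN(c3cccc(C)c3C)CC2)o1`, is not yet measured. Against compound 2 it shows the change (2,3-dimethylphenyl in place of 2,3-dichlorophenyl on an amine nitrogen in a ring). Going by the values given here, no measured pair shows this change, so the size of the step is not known from the series. Two of the three measured compounds gave no number at all, which leaves the expectation cautious: compound 4 is estimated to lose some potency relative to compound 2, the expected step being a 2.6-fold higher number from compound 2 to compound 4 (0.42 log units; beyond the scatter), though a result within the scatter is not excluded. For compound 4 the estimate in this assay is 350 nM, with a range from 100 nM to 2000 nM.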

Compound 4, half-maximal inhibitory concentration: 35 nM
For compound 4 the middle estimate is 10-fold (1.00 log units) above the measured one, and the stated range ends above it.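

For the compounds shown here, on an amine nitrogen in a ring, 2,3-dimethylphenyl in place of 2,3-dichlorophenyl gives a 3.8-fold lower number from compound 2 to compound 4 (0.58 log units; beyond the scatter) in this assay and so provides the first readable step. The earlier compounds shown here could not show this, since compound 2 alone carried a number; compound 4 now shows that a measured inhibition at this position does not require the two chlorine atoms, at least for this one pair. No measurement bears on the reason for the step.

From the compounds shown here alone, whether a 2,3-dimethoxyphenyl or a cyclohexyl group on the same nitrogen would keep or extend the step remains open. Compound 1 and compound 3 differ from compound 2 and compound 4 in more than one place, so their lack of a number cannot be tied to any single change.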